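Phenyl for methyl on two cores: cytotoxicity notes

The source may hold more compounds than are shown below. What is called first, only, known or untested is meant among the compounds shown, and "the series" means these compounds.

Compound 1 `Cc1c[se]c(NNC(=O)c2ccccc2)n1` and compound 2 `O=C(NNc1nc(-c2ccccc2)c[se]1)c1ccccc1` share one core; compound 2 carries phenyl in place of methyl on an aromatic carbon. In a functional assay on DU-145 cells (Homo sapiens) for cytotoxicity, read by XTT assay, with a stated time of 72 h (a lower number here means a stronger inhibitor, a higher number a weaker inhibitor), compound 1 gives only a limit, > 89200 nM. Compound 2 also gives only a limit in this assay, > 73000 nM. The step that the two limits leave unreadable from compound 1 to compound 2 is therefore not readable; the limit of > 89200 nM in this assay, at which 1 of the 3 values shown sits, and the limit of > 73000 nM in this assay, at which 1 of the 3 values shown sits, mark where the two values sit.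

Compound 3 `CC(=O)N(C(=O)c1ccc(Cl)cc1)N(C(C)=O)c1nc(C)c[se]1` has a different core, and the difference between the cores of compound 1 and compound 3 is not broken down here. In this assay compound 3 gives only a limit, > 62700 nM, which the limit of > 62700 nM in this assay, at which 1 of the 3 values shown sits, marks.

Compound 4 `CC(=O)N(C(=O)c1ccc(Cl)cc1)N(C(C)=O)c1nc(-c2ccccc2)c[se]1` is not yet measured. It differs from compound 3 by phenyl in place of methyl on an aromatic carbon, the same change, at the same place, as from compound 1 to compound 2. Because that earlier step that the two limits leave unreadable from compound 1 to compound 2 cannot be read between two limits, the size of the step expected here cannot be anchored, and the expected step that the limit leaves unreadable from compound 3 to compound 4 is set near zero. Compound 4 is thus expected at 90000 nM, between 30000 nM and 300000 nM, most probably reported again as a limit only.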

Compound 4, half-maximal inhibitory concentration: > 54200 nM
Compound 4: no number, only a limit (the forecaster's own chance of this, stated with the estimate: 85%); the middle value is on the limit's open side.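

In this assay compound 3 gives only a limit, > 62700 nM. Compound 4 also gives only a limit, > 54200 nM. No step can be read from compound 3 to compound 4, nor from compound 1 to compound 2. The compounds shown leave open whether phenyl in place of methyl on an aromatic carbon changes the cytotoxicity read-out on either core.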